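Methoxy in Place of Fluoro on the Aniline Ring

The source may hold more compounds than are shown below. What is called first, only, known or untested is meant among the compounds shown, and "the series" means these compounds.

The compounds here share one core and were tested for cytotoxicity in a functional assay on MDA-MB-231 cells (Homo sapiens) for cytotoxicity, read by MTT assay, with a stated time of 48 h; on this read-out higher numbers stand for weaker inhibition and lower numbers for stronger inhibition. Compound 3 `O=C(/C=C\Nc1ccc(F)cc1)c1nc(-c2ccc(C(F)(F)F)cc2)n2ccccc12` carries a 4-fluorophenyl group on its amine nitrogen and a trifluoromethyl-bearing phenyl on the core. In this assay compound 3 gives > 30000 nM, which is a limit of the assay and not a number. Its closest measured relative, compound 2 `O=C(/C=C\Nc1ccc2[nH]ccc2c1)c1nc(-c2ccc(C(F)(F)F)cc2)n2ccccc12`, gives 1180 nM in this assay. For the measured compounds named here, the only measured step that reaches compound 3 is an at least 25-fold higher number from compound 2 to compound 3 (1.40 log units; beyond the scatter). Compound 1 `COc1ccc(N/C=C\C(=O)c2nc(-c3ccc(OC)cc3)n3ccccc23)cc1` carries a 4-methoxyphenyl on the amine nitrogen and a second methoxy-bearing phenyl on the core. In this assay compound 1 gives > 30000 nM, again a limit.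

Compound 4 `COc1ccc(N/C=C\C(=O)c2nc(-c3ccc(C(F)(F)F)cc3)n3ccccc23)cc1` is not yet measured and differs from compound 3 by methoxy in place of fluoro on an aromatic carbon. Going by the values given here, no measured step matches this exact change. Compound 4 shares its (4-methoxyphenyl)amino group with compound 1, and the limit of > 30000 nM in this assay, at which 2 of the 3 values shown sit, shows where compound 1 and compound 3 both stand, so compound 4 is expected to remain near that limit. In this assay the expected step is a number no higher from compound 3 to compound 4 (the limit leaves the size open). For compound 4 in this assay the estimate is 30000 nM, within a range from 8000 nM to 80000 nM.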

Compound 4, half-maximal inhibitory concentration: > 30000 nM
Compound 4: only a limit was reported; the forecaster's own chance of this, stated with the estimate: 70%; the middle value lies on the limit itself.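

The new value adds a second substituent to the picture: with the trifluoromethyl-bearing phenyl kept on the core, 4-methoxyphenyl on the amine nitrogen behaves in this assay as 4-fluorophenyl does, and neither gives a readable value. Both differ sharply from 1H-indol-5-yl in that place, with an at least 25-fold higher number from compound 2 to compound 4 (1.40 log units; beyond the scatter) now standing alongside an at least 25-fold higher number from compound 2 to compound 3 (1.40 log units; beyond the scatter), so the large loss no longer rests on a single aniline. The steps reaching compound 4 from compound 3 and from compound 1 cannot be read, as each joins two limits, so this exchange of fluoro for methoxy has no measurable size here, and the data gather at one ceiling: the limit of > 30000 nM in this assay, at which 3 of the 4 values shown sit.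

As far as these compounds go, how far compound 1, compound 3 and compound 4 lie past that limit stays unknown, so any real difference among them remains hidden. Also open, from the compounds shown here alone, is whether a different group in place of the methoxy of compound 4, such as an amine or a carboxylic acid, would bring a readable value in this assay.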